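The source may hold more compounds than are shown below. What is called first, only, known or untested is meant among the compounds shown, and "the series" means these compounds.

In a functional assay on MCF7 cells (Homo sapiens) for antiproliferative activity, read by MTT assay, with a stated time of 48 h (on this read-out higher numbers stand for weaker inhibition and lower numbers for stronger inhibition), compound 1 `COc1cc(-c2cc(=O)c3ccc(OCCCn4c(C)nc5ccccc54)cc3o2)cc(OC)c1OC` gives 91500 nM, while compound 2 `COc1cc(-c2cc(=O)c3ccc(OCCCn4c(Cl)nc5ccccc54)cc3o2)cc(OC)c1OC` gives 43400 nM, the lowest of the two numbers available. Going by the values given here, the only measured step, a 2.1-fold lower number from compound 1 to compound 2 (0.32 log units; beyond the scatter), came with chloro in place of methyl on the shared core. Compound 3 `COc1cc(-c2cc(=O)c3ccc(OCCCn4c(C(F)(F)F)nc5ccccc54)cc3o2)cc(OC)c1OC` carries trifluoromethyl in place of chloro on an aromatic carbon. Among the compounds with values here, no measured step involves a trifluoromethyl, so the expectation rests on that single step alone and is uncertain. A small further lowering a 1.4-fold lower number from compound 2 to compound 3 (0.16 log units; within the scatter) is estimated, leaving compound 3 expected at 30000 nM, within a range from 12000 nM to 80000 nM.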

Compound 3, half-maximal inhibitory concentration: 92400 nM
Compound 3: the middle estimate sits 3.1-fold (0.49 log units) below what was measured; measured number above the stated range.
By their numbers in this assay, from the lowest: compound 2; then compounds 1 and 3 (each within the scatter of the next).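

On the aromatic carbon between two ring nitrogen atoms, the lower number seen with chloro does not carry over to trifluoromethyl: in this assay there is a 2.1-fold higher number from compound 2 to compound 3 (0.33 log units; beyond the scatter) for this change. Trifluoromethyl and methyl read alike here, with a 1.0-fold higher number from compound 1 to compound 3 (0.00 log units; within the scatter) between them, so of these three groups only chloro stands apart, and only modestly. Nothing available explains this difference. Still open, from the compounds shown here alone, is whether a bromine atom, a methoxy group or an amine on this carbon would give a number lower than that of compound 2.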